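Ring Size at the Thiourea Amide: Cyclopentyl to Cyclohexyl

The source may report more compounds than this note shows. Statements on the series, on what has been measured and on what is new or still open speak of the compounds shown alone.

Compound 1 `O=C(NC(=S)N1CCc2c(OCCCCCOc3ccc(Cl)cc3)cccc21)c1cccc([N+](=O)[O-])c1` gives 12100 nM in an ADME assay on Huh-7 cells (Homo sapiens) for cytotoxicity; on this read-out higher numbers stand for lower toxicity in this test and lower numbers for higher toxicity in this test.
Compound 2 `Cc1ccc(C(=O)NC(=S)N2CCc3c(OCCCCCOc4ccc(Cl)cc4)cccc32)cc1` reaches only the limit > 50000 nM in this assay.
Compound 3 `O=C(NC(=S)N1CCc2c(OCCCCCOc3ccc(Cl)cc3)cccc21)C1CCCC1` reaches only the limit > 50000 nM in this assay.

All three compounds share one core and differ only in the group attached to the carbonyl carbon of the acylthiourea. Compound 3, carrying a cyclopentyl there, stands at the limit of this assay: no number is known for it, only that its toxicity lies beyond the range measured (the limit of > 50000 nM in this assay, at which 2 of the 3 values shown sit). The step of an at least 4.1-fold higher number from compound 1 to compound 3 (0.61 log units; beyond the scatter) shows that replacing the 3-nitrophenyl of compound 1 by cyclopentyl moved the read-out at least modestly toward lower toxicity. The step that the two limits leave unreadable from compound 2 to compound 3 cannot be sized, since both compounds sit at the same limit.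

Compound 4 `O=C(NC(=S)N1CCc2c(OCCCCCOc3ccc(Cl)cc3)cccc21)C1CCCCC1` differs from compound 3 in one place: cyclohexyl in place of cyclopentyl on a carbonyl carbon. This is a small change within the same family of saturated carbocycles, and the steps measured so far give no direct measure of it. Compound 4 is therefore expected to remain near the limit, with an expected step of a number no higher from compound 3 to compound 4 (the limit leaves the size open). The estimate for compound 4 in this assay is 50000 nM, within a range from 20000 nM to 150000 nM.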

Compound 4, half-maximal cytotoxic concentration: > 50000 nM
Compound 4 ended at the assay's limit (the forecaster's own chance of this, stated with the estimate: 70%); the middle value lies on the limit itself.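

With the cyclohexyl of compound 4, a six-membered saturated ring on the carbonyl carbon behaves in this assay as the five-membered ring of compound 3 does: neither gives a measurable half-maximal cytotoxic concentration, so this small enlargement brings no readable toxicity into the test. Among these compounds, replacing the 3-nitrophenyl group by cyclohexyl gives an at least 4.1-fold higher number from compound 1 to compound 4 (0.61 log units; beyond the scatter), so compound 1, with its 3-nitrophenyl group, remains the only one of the four compounds to give a number rather than a limit. The steps among compounds 2, 3 and 4 cannot be read, because these compounds all sit at one shared limit: the limit of > 50000 nM in this assay, at which 3 of the 4 values shown sit.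

On these data alone, whether the lower number of compound 1 follows from the nitro group or from its place on the ring stays open, and a plain phenyl or a 4-nitrophenyl on the same carbonyl carbon would help to separate the two. As far as these compounds go, how far compounds 2, 3 and 4 truly differ also remains unknown, as the limit hides any difference among them.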